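The compounds below may be only part of what the source reports. "The series", "measured", "known", "first", "only" and "open" are said of these compounds alone.

Working notes on the series, step from compound 1 to compound 4. Compound 1 `CO[C@H]1CC[C@H](Nc2cc(NCc3cnccc3C(F)(F)F)ncc2C#N)CC1` is the one member shown without a number: in an assay on isolated protein for inhibition of protein kinase C delta type (Homo sapiens), read by TR-FRET, with a stated time of 2 h (on this read-out higher numbers stand for weaker inhibition and lower numbers for stronger inhibition), compound 1 gives > 10000 nM, which is a limit of the assay and not a measured value (the limit of > 10000 nM in this assay, at which 1 of the 3 values shown sits). For comparison, compound 2 `CC(C)(F)c1ncncc1CNc1cc(N[C@H]2CC[C@@H](O)CC2)c(C#N)cn1` gives 32 nM in this assay, and compound 3 `CC1(C)[C@@H](O)C[C@H]1Nc1nc(NCc2cnccc2C(F)(F)F)ncc1C#N` gives 600 nM in this assay. Compound 4 `CC1(C)[C@@H](C(N)=O)C[C@H]1Nc1cc(NCc2cnccc2C(F)(F)F)ncc1C#N` is the next to be measured in this assay. Its change from compound 1 is 3-carbamoyl-2,2-dimethylcyclobutyl in place of 4-methoxycyclohexyl on a nitrogen on an aromatic ring. Among the measured compounds shown here, no pair of measured compounds differs in only this place, so the size of the step is open; a gain on compound 1, beyond the scatter, is expected rather than none. Compound 4 is expected at 1500 nM, between 300 nM and 8000 nM. The step this estimate means, an at least 6.6-fold lower number from compound 1 to compound 4 (0.82 log units; beyond the scatter), is an expectation only.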

Compound 4, half-maximal inhibitory concentration: 160 nM
Beside the measured number, compound 4's estimate is 9.4-fold (0.97 log units) above it; the measured number lies below the stated range.
By their numbers in this assay, from the lowest: compound 2; then compound 4; then compound 3. At a limit, above all of these: compound 1.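

On a nitrogen on an aromatic ring, 3-carbamoyl-2,2-dimethylcyclobutyl in place of 4-methoxycyclohexyl gives, in this assay, an at least 62-fold lower number from compound 1 to compound 4 (1.79 log units; beyond the scatter). Among the compounds shown here, this is the first single-place change, and it shows that the group at this position alone can move the read-out by a large step. The value of compound 1 is a limit of the assay, so the step gives only a minimum size: the limit of > 10000 nM in this assay, at which 1 of the 4 values shown sits.

Going by these compounds, the change alters ring size, the carbamoyl and the dimethyl substitution together, and their separate shares remain open. A carboxylic acid in place of the carbamoyl, or a carbamoyl on a six-membered ring, would bear on this.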